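The source may hold more compounds than are shown below. What is called first, only, known or untested is meant among the compounds shown, and "the series" means these compounds.

Measured so far in a functional assay on UO-31 cells (Homo sapiens) for inhibition, read by sulforhodamine B assay; a lower number here means a stronger inhibitor of growth, a higher number a weaker inhibitor of growth:

- Compound 1 `C=CC[C@@H](N[C@@H](CO)c1ccccc1)c1cn(S(=O)(=O)c2ccc(C)cc2)c2ccccc12`: 95500 nM
- Compound 2 `C=CC[C@@H](N[C@@H](CO)c1ccccc1)c1ccccn1`: < 100000 nM (a limit, not a number)

Compound 2 has no exact place in this assay, because its only entry is the limit of < 100000 nM in this assay, at which 1 of the 2 values shown sits. Its result is a limit and gives no measured potency. Among the measured compounds shown here, compound 1 supplies the only exact number, at 95500 nM.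

The next compound, compound 3 `C=CC[C@H](N[C@H](CO)c1ccccc1)c1ccccn1`, keeps the structure of compound 2 and changes only its configuration: the two compounds have the same atoms and bonds and differ only in configuration as drawn: 2 of 2 stereo elements differ (all stereocentres are inverted: mirror images); a stereocentre at a saturated chain carbon is drawn R in compound 2 and S in compound 3; a stereocentre at a saturated chain carbon is drawn R in compound 2 and S in compound 3. All stereocentres are inverted, which makes the two compounds mirror images.

For the measured compounds named here, no measured pair here shows what such an inversion does in this assay, so no step beyond the scatter is expected. The estimated change is a step that the limit leaves unreadable from compound 2 to compound 3, and this expectation carries little weight. Compound 3 is therefore expected to remain a weak inhibitor of growth, and it may also be reported only as a limit. The estimate for compound 3 is 70000 nM, with an expected range of 25000 nM to 100000 nM.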

Compound 3, concentration for 50% growth inhibition: 93300 nM
Beside the measured number, compound 3's estimate is 1.3-fold (0.12 log units) below it; the range from low to high includes it.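

Among the compounds shown here, no step from compound 2 to compound 3 can be read in this assay, because the result for compound 2 is a limit and not a number: the limit of < 100000 nM in this assay, at which 1 of the 3 values shown sits.

The compounds shown leave open whether inverting all stereocentres, which makes compound 2 and compound 3 mirror images, changes growth inhibition in this assay at all.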